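The source may hold more compounds than are shown below. What is called first, only, known or untested is meant among the compounds shown, and "the series" means these compounds.

Compound 1 `N#Cc1ccc(Nc2nccc(C(O)c3ccc(-c4ccc(C#N)cc4)cc3F)n2)cc1`, in an ADME assay on MT4 cells (Homo sapiens) for cytotoxicity, read by MTT assay, with a stated time of 5 days (a lower number here means that less compound is tolerated, a higher number that more compound is tolerated), compound 1 gives 14300 nM.
Compound 2 `N#Cc1ccc(Nc2nccc([C@H](O)c3ccc(-c4ccc(C#N)cc4)cc3F)n2)cc1`, in this assay compound 2 gives 30000 nM.

For the measured compounds named here, compound 2 holds the highest of the two numbers measured; the only other compound, compound 1, sits at a lower value, and the step of a 2.1-fold higher number from compound 1 to compound 2 (0.32 log units; beyond the scatter) is the one measured step. That step turns on (the fact that one of compounds 1 and 2 is drawn with a defined configuration and the other without, at the place where they differ), not on any change of atoms.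

Compound 3 `N#Cc1ccc(Nc2nccc([C@H](O)c3ccc(-c4ccc(C#N)cc4)cc3C(F)(F)F)n2)cc1` carries trifluoromethyl in place of fluoro on an aromatic carbon. Going by the values given here, no measured step shows a change of this kind, since the single measured step concerns only the drawn configuration of a stereocentre, so the data offer no guide to direction or size here. Compound 3 is therefore expected to sit near compound 2, with a 1.2-fold lower number from compound 2 to compound 3 (0.08 log units; within the scatter) as the estimated step, not expected to exceed the scatter. For compound 3 the estimate in this assay is 25000 nM, within a range from 10000 nM to 60000 nM.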

Compound 3, half-maximal cytotoxic concentration: 24100 nM
Compound 3: the middle estimate sits 1.0-fold (0.02 log units) above what was measured, within the range that was stated.
By their numbers in this assay, from the lowest: compounds 1, 3 and 2 (each within the scatter of the next, the first and the last beyond it).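

At this position, on an aromatic carbon ortho to a large group, the series now shows its first measured change of atoms, as a 1.2-fold lower number from compound 2 to compound 3 (0.10 log units; within the scatter) replaces fluoro with trifluoromethyl; the earlier step concerned only a drawn configuration. Trifluoromethyl, with 4 heavy atoms, stands where fluoro, with 1 heavy atom, stood, and this assay does not separate the two compounds, so at this place the exchange leaves the number within the scatter. Nothing available gives a reason for this result.

The compounds shown leave open how an amine, a carboxylic acid or a methoxy group on this aromatic carbon would read in this assay. They also leave open whether the same exchange would read alike with the stereocentre drawn without a configuration, as in compound 1.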